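Working notes: amino-to-hydroxy swap in a cytotoxicity series

A few compounds are considered here, and "the series" means these few. Any claim that something is new, unique, unknown or untested is made for them only; others in the source may bear on it.

Measured so far, in a functional assay on A549 cells (Homo sapiens) for cytotoxicity, read by MTT assay, with a stated time of 72 h; on this read-out higher numbers stand for weaker inhibition and lower numbers for stronger inhibition:
compound 1 `Cc1ccc(S(=O)(=O)c2nc3ccccc3nc2Nc2cccc(N)c2)cc1` gives 1950 nM
compound 2 `Cc1ccc(S(=O)(=O)c2nc3ccccc3nc2Nc2cccc(O)c2)cc1` gives 6080 nM
compound 3 `Nc1cccc(Nc2nc3ccccc3nc2S(=O)(=O)c2ccc(Br)cc2)c1` gives 1120 nM

Compound 1 and compound 2 share everything but one group, (hydroxy in place of amino on an aromatic carbon). That change gives a 3.1-fold higher number from compound 1 to compound 2 (0.49 log units; beyond the scatter). Compound 1 and compound 3 differ in their cores, (bromo in place of methyl on an aromatic carbon), and this gives a 1.7-fold lower number from compound 1 to compound 3 (0.24 log units; within the scatter).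

Compound 4 `O=S(=O)(c1ccc(Br)cc1)c1nc2ccccc2nc1Nc1cccc(O)c1` is not yet measured. It differs from compound 3 by hydroxy in place of amino on an aromatic carbon, and the place of the change is the same word for word as for the pair compound 1 to compound 2, so it is the same change, only on the core of compound 3 rather than the core of compound 1. The two cores differ as told above by bromo in place of methyl on an aromatic carbon.

Because the change from compound 1 to compound 2 gave a 3.1-fold higher number from compound 1 to compound 2 (0.49 log units; beyond the scatter), a step of about the same size is expected here, namely a 3.1-fold higher number from compound 3 to compound 4 (0.49 log units; beyond the scatter). On that basis compound 4 is expected to give 3500 nM in this assay, with the estimate spanning 1800 nM to 7000 nM.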

Compound 4, half-maximal inhibitory concentration: 8000 nM
Beside the measured number, compound 4's estimate is 2.3-fold (0.36 log units) below it; measured number above the stated range.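

In this assay, hydroxy in place of amino on the bromo-bearing core gives a 7.1-fold higher number from compound 3 to compound 4 (0.85 log units; beyond the scatter), the same direction as on the methyl-bearing core, and the two steps do not differ beyond the scatter: the same change on two cores in this assay, a 3.1-fold higher number (0.49 log units; beyond the scatter) from compound 1 to compound 2 and a 7.1-fold higher number (0.85 log units; beyond the scatter) from compound 3 to compound 4, 2.3-fold (0.36 log units) apart, within the scatter of two such steps. Bromo in place of methyl, read on the hydroxy pair, gives a 1.3-fold higher number from compound 2 to compound 4 (0.12 log units; within the scatter), and this step also does not differ beyond the scatter from its counterpart on the amino pair: the same change on two cores in this assay, a 1.7-fold lower number (0.24 log units; within the scatter) from compound 1 to compound 3 and a 1.3-fold higher number (0.12 log units; within the scatter) from compound 2 to compound 4, 2.3-fold (0.36 log units) apart, within the scatter of two such steps. The amino-to-hydroxy change therefore carries across these two cores as a higher number on both, but two pairs do not fix the size of the step or show that it holds on any other core.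

The compounds shown leave open whether the step persists when a methoxy group or a carboxylic acid takes the place of hydroxy at the same position. They also leave open whether it persists when a chloro group or a hydrogen takes the place of bromo or methyl on the core.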